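The source may hold more compounds than are shown below. What is called first, only, known or untested is meant among the compounds shown, and "the series" means these compounds.

Compound 1 `COc1cccc(/C=C2\CCC/C(=C\c3cccc(O)c3)C2=O)c1OC`: > 20000 nM
Compound 2 `COc1ccc(/C=C2\CCC/C(=C\c3ccccc3Br)C2=O)cc1OC`: > 20000 nM

Both numbers come from a functional assay on A549 cells (Homo sapiens) for cytotoxicity, read by MTT assay, with a stated time of 72 h; a lower number here means a stronger inhibitor, a higher number a weaker inhibitor. For compound 1 the value > 20000 nM is a limit of the assay rather than a measured number. For compound 2 the value > 20000 nM is likewise a limit and not a number. Among the measured compounds shown here, compound 2 therefore stands exactly where the only other measured compound stands: the limit of > 20000 nM in this assay, at which 2 of the 2 values shown sit. For the measured compounds named here, no step between measured compounds that differ in one place exists here, so nothing yet shows how far a change on this part of the shared core moves the read-out in this assay.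

Compound 3 `COc1ccc(/C=C2\CCC/C(=C\c3ccc(Cl)cc3Cl)C2=O)cc1OC` has not been measured. It differs from compound 2 in one place: 2,4-dichlorophenyl in place of 2-bromophenyl on a double-bonded chain carbon bound to a double-bonded ring carbon. With both measured values sitting at the limit, the step expected from this change is none beyond the scatter. The step estimated here is a step that the limit leaves unreadable from compound 2 to compound 3. The expected result for compound 3 in this assay is 30000 nM, with a range from 10000 nM to 100000 nM, most likely reported again only as a limit.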

Compound 3, half-maximal inhibitory concentration: > 20000 nM
Compound 3: a limit, no number (the forecaster's own chance of this, stated with the estimate: 75%); the middle value does not contradict the limit.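

In this assay compound 3 gives > 20000 nM, which is a limit and not a number. Among the compounds shown here, compound 2 also stands at a limit, so no step between compound 2 and compound 3 can be read. The compounds shown leave open whether any change on the shared core would give a real number, since all share one reading: the limit of > 20000 nM in this assay, at which 3 of the 3 values shown sit.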